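The compounds below may be only part of what the source reports. "The series", "measured", "known", "first", "only" and "open" are said of these compounds alone.

Values in a toxicity assay on MDCK cells (Canis lupus familiaris) for cytotoxicity, read by CCK-8 assay, with a stated time of 48 h; on this read-out higher numbers stand for lower toxicity in this test and lower numbers for higher toxicity in this test:
Compound 1 `O=C(NNc1c(Br)cccc1Br)c1ccc(-c2ccccc2)cc1`: 84100 nM
Compound 2 `CCCc1ccc(C(=O)NNc2c(Cl)cccc2Cl)cc1`: > 100000 nM, a limit
Compound 3 `CCOc1ccc(C(=O)NNc2c(F)cccc2F)cc1`: > 100000 nM, a limit

Compound 3 has no actual number, and its > 100000 nM in this assay is a limit. That places it at the limit of > 100000 nM in this assay, at which 2 of the 3 values shown sit.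

Compound 4 `CN(C)c1ccc(C(=O)NNc2c(F)cccc2F)cc1` arises from compound 3 by one change, dimethylamino in place of ethoxy on an aromatic carbon, para to a large group. Going by the values given here, no measured pair tests this exchange. Among the compounds with values here, compound 1, at 84100 nM, holds the only actual number and anchors the lower side of the expectation. The expected change is none beyond the scatter, with an at least 1.1-fold lower number from compound 3 to compound 4 (0.04 log units; that floor lies within the scatter) as the estimated step. For compound 4 the estimate is 90000 nM, with an expected range of 40000 nM to 150000 nM.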

Compound 4, half-maximal cytotoxic concentration: > 100000 nM
Compound 4: only a limit was reported (the forecaster's own chance of this, stated with the estimate: 60%); at least 1.1-fold (0.04 log units) between middle value and limit.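

Compound 3 and compound 4 both give only a limit in this assay, so no step between them can be read: the limit of > 100000 nM in this assay, at which 3 of the 4 values shown sit.

Going by these compounds, whether dimethylamino in place of ethoxy on an aromatic carbon shifts this read-out at all remains open.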